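Swapping 2-Fluorophenyl for 4-Bromophenyl in Compound 3

The source may hold more compounds than are shown below. What is called first, only, known or untested is meant among the compounds shown, and "the series" means these compounds.

Cell tolerance is the question here, and the three measured compounds give little to separate them. In an ADME assay on MDBK cells (Bos taurus) for cytotoxicity (a lower number here means that less compound is tolerated, a higher number that more compound is tolerated), compound 1 `Fc1cccc(F)c1Cn1ccc2nc(-c3c(F)cccc3F)nc-2c1` gives > 100000 nM, which is a limit of the assay and not a number. Compound 2 `Fc1cccc(F)c1Cn1c(-c2c(F)cccc2F)nc2cnccc21` gives > 100000 nM, again a limit. Compound 3 `Fc1ccccc1Cn1ccc2nc(-c3ccccc3)nc-2c1` gives > 100000 nM, also a limit. Compound 3 therefore has no exact value, and its place is shared with the other two: the whole picture is the limit of > 100000 nM in this assay, at which 3 of the 3 values shown sit. Going by the values given here, no step between measured compounds can be read from these results, so any forecast rests on thin ground.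

Compound 4 `Brc1ccc(Cn2ccc3nc(-c4ccccc4)nc-3c2)cc1` differs from compound 3 in one place, with 4-bromophenyl in place of 2-fluorophenyl on a saturated chain carbon bound to an aromatic nitrogen. The shared core stays the same. Among the compounds with values here, with no measured compound showing a number in this assay, only a small change is expected, perhaps toward a lower number, and it may not go beyond the usual scatter. This expectation amounts to an estimated at least 1.2-fold lower number from compound 3 to compound 4 (0.09 log units; that floor lies within the scatter). For compound 4 the estimated value is 80000 nM, with an expected range from 25000 nM to 150000 nM.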

Compound 4, half-maximal cytotoxic concentration: 83000 nM
Compound 4: middle estimate off by 1.0-fold (0.02 log units), on the low side, within the range that was stated.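

In this assay compound 4 gives 83000 nM, the only exact number among the compounds shown. The others stay at a limit of the assay: the limit of > 100000 nM in this assay, at which 3 of the 4 values shown sit.

At this position, on a saturated chain carbon bound to an aromatic nitrogen, replacing 2-fluorophenyl with 4-bromophenyl gives an at least 1.2-fold lower number from compound 3 to compound 4 (0.08 log units; that floor lies within the scatter). Compound 3 has only a limit, so this step is a floor: the true gap could be larger, but the floor alone does not establish a real change in how much compound the cells tolerate.

The swap exchanges fluorine for bromine and also changes the number in the group's name, so these compounds cannot separate the effect of the halogen from the effect of where it sits on the phenyl ring. On these data alone, it also remains open whether a phenyl ring carrying an amine or a carboxylic acid at this position would give a clearer step, one that lies beyond the usual scatter of this kind of measurement.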